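Removing One Chloro Group: What Compound 3 Should Show

The source may report more compounds than this note shows. Statements on the series, on what has been measured and on what is new or still open speak of the compounds shown alone.

Measured compounds:
compound 1, `O=C(Nc1cccc(-n2cc(-c3ccncc3)c(-c3cc(O)cc(Cl)c3)n2)c1)Nc1ccc(Cl)c(Cl)c1`: 99%
compound 2, `COc1cc(Cl)cc(-c2nn(-c3cccc(NC(=O)Nc4ccc(Cl)c(C(F)(F)F)c4)c3)cc2-c2ccncc2)c1`: 93%

In a functional assay on UACC-62 cells (Homo sapiens) for inhibition, read by sulforhodamine B assay, with a stated time of 48 h, tested at 0.1 uM (on this read-out higher numbers stand for a weaker effect at the one concentration tested and lower numbers for a stronger effect), compound 1 gives 99%, and in this assay compound 2 gives 93%. Compound 2 holds the lower of the two numbers, but its nearest neighbour, compound 1, sits only a little higher, a gap within the scatter, so no order between them is claimed. Both numbers lie near the top of the scale in this assay.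

Compound 3, `COc1cc(Cl)cc(-c2nn(-c3cccc(NC(=O)Nc4cccc(C(F)(F)F)c4)c3)cc2-c2ccncc2)c1`, differs from compound 2 by hydrogen in place of chloro on an aromatic carbon. Among the measured compounds shown here, no step between measured compounds is known, so the expectation rests on the two numbers themselves. Compound 3 is expected to move, if at all, by a number 2 percentage points higher from compound 2 to compound 3 (within the scatter), a step within the scatter and with no clear direction. Compound 3 is therefore estimated at 95% in this assay, with a range from 80% to 106%.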

Compound 3, a percentage reported as activity, at one concentration (the size of the read-out at that concentration, not a potency): 96%
Compound 3: the middle estimate sits 1 percentage points below what was measured, and the stated range covers the measured number.
By their numbers in this assay, from the lowest: compounds 2, 3 and 1 (each within the scatter of the next).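

In this assay, among the compounds shown here, the first step at this position, where the 4-chloro-3-(trifluoromethyl)phenyl group becomes 3-(trifluoromethyl)phenyl, reads a number 3 percentage points higher from compound 2 to compound 3 (within the scatter). On this aromatic carbon, ortho to a trifluoromethyl group and para to a large group, chloro and hydrogen therefore cannot be told apart at the one concentration tested, so this chloro is not shown to matter for the read-out in this pair. Nothing available here explains this result. From the compounds shown here alone, whether an amine or a carboxylic acid on the same carbon would give a number clearly apart from those of compound 2 and compound 3 remains open. Also open, going by these compounds, is whether hydrogen in place of this chloro would read the same way on a compound whose number lies well away from the top of the scale.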